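The compounds below may be only part of what the source reports. "The series", "measured", "known", "first", "only" and "open" are said of these compounds alone.

Of the compounds shown here, three sharing one core have been tested in a functional assay on MCF7 cells (Homo sapiens) for inhibition, read by MTT assay, with a stated time of 72 h; a higher number here means a weaker inhibitor, a lower number a stronger inhibitor. In this assay, compound 1 (`CC(=O)N1CCN(c2nnc3nncn3n2)CC1`) gives 13900 nM. Compound 2 (`OCCNc1nnc2nncn2n1`) gives 11600 nM, which lies within the usual scatter of the value for compound 1, so the two cannot be ranked. Compound 3 (`OCC(CO)(CO)Nc1nnc2nncn2n1`) is reported only as a limit, > 100000 nM, and this is not a number. For the measured compounds named here, compound 1 therefore stands level with compound 2, the only other compound with a measured number.

Compound 4 (`CCCCCC(=O)N1CCN(c2nnc3nncn3n2)CC1`) has not yet been measured in this assay. It differs from compound 1 in one place: butyl in place of hydrogen on a saturated chain carbon bound to a carbonyl carbon. This is butyl in place of hydrogen on a saturated chain carbon bound to a carbonyl carbon, so that the acetyl of compound 1 becomes pentylcarbonyl, or, read one bond further out, methyl becomes pentyl.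

Going by the values given here, no measured pair of compounds shows a change of this kind, so the expectation is a cautious one. A modest move toward a lower number is expected, though a result within the scatter of compound 1 would fit as well. The expected size of this change is a 2.0-fold lower number from compound 1 to compound 4 (0.30 log units; within the scatter). The estimate for compound 4 is 7000 nM, within an expected range of 2000 nM to 25000 nM.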

Compound 4, half-maximal inhibitory concentration: 5260 nM
The estimate for compound 4 lay 1.3-fold (0.12 log units) above the measured number; the measured number falls inside the stated range.
By their numbers in this assay, from the lowest: compound 4; then compounds 2 and 1 (each within the scatter of the next). At a limit, above all of these: compound 3.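

For the compounds shown here, until this result, no two compounds differing in one place had been compared, so nothing was known about how the number responds to a change at this position. In this assay there is now a 2.6-fold lower number from compound 1 to compound 4 (0.42 log units; beyond the scatter) and this is the one step shown that lies beyond the scatter, with butyl in place of hydrogen on a saturated chain carbon bound to a carbonyl carbon. The position therefore accepts a chain of this size without loss, and turning the acetyl of compound 1 into pentylcarbonyl moves the number modestly downward, though nothing shown accounts for that move.

As far as these compounds go, a single step gives two points and no trend, so it remains open whether an ethyl or propyl chain would give an intermediate number, and whether a chain longer than pentyl would lower the number further, leave it level or raise it. Also open, from the compounds shown here alone, is how the number would respond if the pentyl were replaced by a phenyl ring, or if the chain ended in an amine or a carboxylic acid.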